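A few compounds are considered here, and "the series" means these few. Any claim that something is new, unique, unknown or untested is made for them only; others in the source may bear on it.

Measured so far:
- compound 1 `CCOC(=O)c1sc(-c2cccc(NC(=O)c3ccc(Cl)cc3)c2)nc1Nc1ccc(N2CCN(C)CC2)cc1`: 24.3%
- compound 2 `CCOC(=O)c1sc(-c2cccc(NC(=O)c3ccc(C#N)cc3)c2)nc1Nc1ccc(N2CCN(C)CC2)cc1`: 79.1%
- compound 3 `CCOC(=O)c1sc(-c2cccc(NC(=O)c3ccc(C(F)(F)F)cn3)c2)nc1Nc1ccc(N2CCN(C)CC2)cc1`: 20.8%

In a functional assay on Raji cells (Homo sapiens) for antiproliferative activity, read by CCK-8 assay, with a stated time of 72 h, tested at 40 uM (a lower number here means less inhibition, a higher number more inhibition at the concentration tested (going by the name of the read-out)), compound 1 gives 24.3%, the second highest of the three numbers. Compound 3 stands nearest to it: a number 3.5 percentage points lower from compound 1 to compound 3 (within the scatter). Compound 2 stands furthest: a number 54.8 percentage points higher from compound 1 to compound 2 (beyond the scatter). The third measured step is a number 58.3 percentage points lower from compound 2 to compound 3 (beyond the scatter). All three steps vary the aryl on the amide carbonyl and leave the ester untouched.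

Compound 4 `CN1CCN(c2ccc(Nc3nc(-c4cccc(NC(=O)c5ccc(Cl)cc5)c4)sc3C(=O)O)cc2)CC1` is the next compound. Its difference from compound 1 is hydrogen in place of ethyl on an oxygen next to a carbonyl group. Going by the values given here, no measured step touches this place, so the measured steps give no direct guide; the shared core and the amide aryl of compound 1 are kept unchanged. With nothing in the data pointing either way, the expectation is no step beyond the scatter, that is a number 0.3 percentage points lower from compound 1 to compound 4 (within the scatter). Compound 4 is therefore estimated at 24% in this assay, with a range from 5% to 50%, the width reflecting that the ester position has not been explored.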

Compound 4, a percentage reported as inhibition, at one concentration (the size of the read-out at that concentration, not a potency): 90.9%
Compound 4: the middle estimate sits 66.9 percentage points below what was measured; measured number outside the range, above it.
By their numbers in this assay, from the lowest: compounds 3 and 1 (each within the scatter of the next); then compound 2; then compound 4.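

In this assay, going by these compounds alone, the ethoxycarbonyl group is the first place outside the amide aryl to be varied, and carboxy in its place gives a number 66.6 percentage points higher from compound 1 to compound 4 (beyond the scatter). The amide aryl is therefore not the only place that moves this read-out: with the 4-chlorophenyl amide held fixed, this change is large, as is the cyano in place of chloro change on the amide aryl, a number 54.8 percentage points higher from compound 1 to compound 2 (beyond the scatter). Nothing available here accounts for the size of the step from ester to carboxy.

From the compounds shown here alone, whether the carboxy change adds to the cyano change when both are present on the shared core remains open. Also open, going by these compounds, is whether the step depends on the free carboxylic acid or simply on losing the ethyl, which a methyl ester, a longer chain ester or a primary amide at this place could help separate.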